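Aryl swap on the shared core: outlook for compound 3

A few compounds are considered here, and "the series" means these few. Any claim that something is new, unique, unknown or untested is made for them only; others in the source may bear on it.

Measured so far:
compound 1 `COc1cc(-c2ccnc3cc(-c4ccc(F)cc4)nn23)cc(OC)c1OC` — 5030 nM
compound 2 `COc1cc(-c2ccnc3cc(-c4ccc(C(F)(F)F)cc4)nn23)cc(OC)c1OC` — 1860 nM

Among the measured compounds shown here, in a functional assay on HCT-116 cells (Homo sapiens) for inhibition, read by CCK-8 assay, with a stated time of 48 h (on this read-out lower numbers stand for stronger inhibition and higher numbers for weaker inhibition), compound 2 gives the lowest of the two numbers; the only measured step is a 2.7-fold lower number from compound 1 to compound 2 (0.43 log units; beyond the scatter), which places compound 1 as the weaker of the pair, at 5030 nM.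

Compound 3 `COc1ccc(-c2cc3nccc(-c4cc(OC)c(OC)c(OC)c4)n3n2)cc1F` differs from compound 2 by 3-fluoro-4-methoxyphenyl in place of 4-(trifluoromethyl)phenyl on an aromatic carbon. For the measured compounds named here, the one measured step bears on this only in part: it compared trifluoromethyl against fluoro, and going from compound 2 to compound 3 the trifluoromethyl leaves while a fluoro returns, now joined by a methoxy. Going by the values given here, no measured pair tells what a methoxy entering does. Undoing the trifluoromethyl is read as undoing most of the step seen between compound 1 and compound 2, so compound 3 is expected to land between the two, with the step of a 1.9-fold higher number from compound 2 to compound 3 (0.27 log units; within the scatter) in this assay. The estimate for compound 3 is 3500 nM, range 1500 nM to 8000 nM.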

Compound 3, half-maximal inhibitory concentration: 2840 nM
Estimate against measurement, compound 3: 1.2-fold (0.09 log units) above; the measured number falls inside the stated range.
By their numbers in this assay, from the lowest: compounds 2, 3 and 1 (each within the scatter of the next, the first and the last beyond it).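

In this assay, 3-fluoro-4-methoxyphenyl on this aromatic carbon of the five-membered ring gives a 1.5-fold higher number from compound 2 to compound 3 (0.18 log units; within the scatter) and a 1.8-fold lower number from compound 1 to compound 3 (0.25 log units; within the scatter), so compound 3 cannot be separated from either compound 1 or compound 2, although those two differ beyond the scatter. The position therefore tolerates a methoxy together with a fluoro on the aryl ring, with neither step beyond the scatter, which a comparison of 4-fluorophenyl and 4-(trifluoromethyl)phenyl alone could not show. Nothing available gives a cause for these steps.

On these data alone, what the methoxy and the fluoro of compound 3 each contribute stays open, as they appear only together. Also open, as far as these compounds go, is whether an amine or a carboxylic acid on this aryl ring, or a longer alkoxy chain in place of the methoxy, would move the number beyond the scatter.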